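The compounds below may be only part of what the source reports. "The series", "measured", "known", "first", "only" and "open" are said of these compounds alone.

Measured compounds:
- compound 1, `Cn1c(Cc2nn(C)c(=O)c3ccccc23)nnc1SCCCCCCCC(=O)Nc1ccc(Br)cc1Br`, in an assay on cells for inhibition of IL15-IL15 receptor (Homo sapiens), read by AlphaScreen, with stated times of 30 min and 1 h (a higher number here means a weaker inhibitor, a lower number a stronger inhibitor), gives 92000 nM
- compound 2, `COc1ccc(NC(=O)CCCCCCCSc2nnc(Cc3nn(C)c(=O)c4ccccc34)n2C)cc1`, in this assay gives 201000 nM

Compound 2 stands at the higher of the two numbers, so it is the weaker inhibitor of the pair. Among the measured compounds shown here, the single step measured so far is a 2.2-fold higher number from compound 1 to compound 2 (0.34 log units; beyond the scatter), a modest step beyond the scatter, where a 4-methoxyphenyl replaced a 2,4-dibromophenyl on the amide-type nitrogen at the end of the chain. For the measured compounds named here, that is the only guide available.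

Compound 3, `Cc1ccc(NC(=O)CCCCCCCSc2nnc(Cc3nn(C)c(=O)c4ccccc34)n2C)c(Cl)c1`, has not been measured. It differs from compound 2 in one place: 2-chloro-4-methylphenyl in place of 4-methoxyphenyl on an amide-type nitrogen. The ring that enters carries a chlorine and a methyl rather than a methoxy, which brings it nearer in kind to the halogen-bearing ring of compound 1 than to the methoxy ring of compound 2. On the strength of that one step the expected direction is a somewhat lower number, roughly partway back toward compound 1, though the size is uncertain. Compound 3 is therefore estimated to give 120000 nM in this assay, within a range of 50000 nM to 300000 nM, which means an expected step of a 1.7-fold lower number from compound 2 to compound 3 (0.22 log units; within the scatter).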

Compound 3, half-maximal inhibitory concentration: 76000 nM
Compound 3: middle estimate off by 1.6-fold (0.20 log units), on the high side; low and high end bracket the measured number.
By their numbers in this assay, from the lowest: compounds 3 and 1 (each within the scatter of the next); then compound 2.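

Replacing the 4-methoxyphenyl on the amide-type nitrogen with 2-chloro-4-methylphenyl gives a 2.6-fold lower number from compound 2 to compound 3 (0.42 log units; beyond the scatter) in this assay, which makes compound 2 the weakest of the three inhibitors and shows that a second, differently substituted ring also gives a lower number than the methoxy ring. Going from the dibromo ring to the chloro-methyl ring gives a 1.2-fold lower number from compound 1 to compound 3 (0.08 log units; within the scatter) and so makes no real difference, which means that in these compounds the two bromines are not needed to reach this level, since a ring with one chlorine and one methyl does as well. Nothing given here explains why the methoxy ring stands apart from the other two.

Because the chlorine and the methyl enter together, these three compounds cannot say whether either one alone would be enough, or whether a plain phenyl would behave like the methoxy ring or like the other two. They also leave open what an amine or a carboxylic acid on this ring would do, and whether a longer chain would shift all of these numbers.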